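A few compounds are considered here, and "the series" means these few. Any claim that something is new, unique, unknown or untested is made for them only; others in the source may bear on it.

Compound 1 `CCCCCCCCCCc1ccc(-c2noc(CCCCN)n2)cc1` carries a 4-aminobutyl group on the shared core. In an assay on HeLa cells for inhibition of sphingosine-1-phosphate transporter SPNS2 (Mus musculus), read by LC-MS, tested at 2 uM (on this read-out lower numbers stand for less inhibition and higher numbers for more inhibition at the one concentration tested (going by the name of the read-out)), compound 1 gives 55%, the second highest of the three numbers. Compound 2 `CCCCCCCCCCc1ccc(-c2noc(CCCN(C)C)n2)cc1` gives 8%, and compound 3 `CCCCCCCCCCc1ccc(-c2noc(CC3CNC3)n2)cc1` gives 63%. The step of a number 47 percentage points lower from compound 1 to compound 2 (beyond the scatter) is large, whereas the step of a number 8 percentage points higher from compound 1 to compound 3 (within the scatter) stays within the scatter, as does the gap between compound 1 and compound 3 in either direction.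

Compound 4 `CCCCCCCCCCc1ccc(-c2noc(C(Cl)CCN)n2)cc1` has not been measured. Relative to compound 1 the change is a group of 5 heavy atoms (3 carbon, 1 nitrogen, 1 chlorine; no ring) in place of a group of 5 heavy atoms (4 carbon, 1 nitrogen; no ring), on an aromatic carbon. The entering group keeps 1 hydrogen-bond donor and 1 hydrogen-bond acceptor, like the leaving 4-aminobutyl group; the nitrogen is not turned into a dimethylamino group, so the large drop seen in a number 47 percentage points lower from compound 1 to compound 2 (beyond the scatter) does not bear directly on this step. The unchanged number in a number 8 percentage points higher from compound 1 to compound 3 (within the scatter), where the chain was reshaped while a basic nitrogen remained, is the closer guide. A step near a number 10 percentage points lower from compound 1 to compound 4 (within the scatter) is therefore expected, perhaps a small loss. Compound 4 is estimated to give 45% in this assay, within a range from 20% to 70%.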

Compound 4, a percentage reported as inhibition, at one concentration (the size of the read-out at that concentration, not a potency): 5%
For compound 4 the middle estimate is 40 percentage points above the measured one; the whole stated range lies above it.
By their numbers in this assay, from the lowest: compounds 4 and 2 (each within the scatter of the next); then compounds 1 and 3 (each within the scatter of the next).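

Within this assay, the chlorine-bearing group matches the 4-aminobutyl group in its counts of heavy atoms, hydrogen-bond donors and hydrogen-bond acceptors, yet the change gives a number 50 percentage points lower from compound 1 to compound 4 (beyond the scatter). Keeping a nitrogen in the group at this position is therefore not enough to keep the inhibition, as the comparison with the azetidine also shows: a number 58 percentage points lower from compound 3 to compound 4 (beyond the scatter). The chlorine-bearing group lands level with the dimethylamino compound, with a number 3 percentage points lower from compound 2 to compound 4 (within the scatter), so two quite different changes to the group now end at the same low level.

From the compounds shown here alone, whether the loss is specific to chlorine remains open, since a fluorine atom or a hydroxyl group in its place could be read differently. The data shown offer no explanation for the loss.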